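Replacing (isopropylcarbonyl)oxy with methanesulfonamido on a saturated ring

The source may report more compounds than this note shows. Statements on the series, on what has been measured and on what is new or still open speak of the compounds shown alone.

Compound 1 `CS(=O)(=O)OC1CCC(CN2CCN(c3cc(=O)c4cc(C(F)(F)F)cc([N+](=O)[O-])c4s3)CC2)CC1`: > 64 ug/mL
Compound 2 `CC(C)C(=O)OC1CCC(CN2CCN(c3cc(=O)c4cc(C(F)(F)F)cc([N+](=O)[O-])c4s3)CC2)CC1`: > 64 ug/mL
Compound 3 `CS(=O)(=O)NC1CCC(CN2CCN(c3cc(=O)c4cc(C(F)(F)F)cc([N+](=O)[O-])c4s3)CC2)CC1`: not yet measured

In an ADME assay on Vero cells (Chlorocebus sabaeus) for cytotoxicity, read by MTT assay, with a stated time of 48 h (a lower number here means a stronger inhibitor, a higher number a weaker inhibitor), compound 2 gives > 64 ug/mL, which is a limit and not a number. The record so far reads (the limit of > 64 ug/mL in this assay, at which 2 of the 2 values shown sit). Compound 3 carries methanesulfonamido in place of (isopropylcarbonyl)oxy on a saturated ring carbon. Among the compounds with values here, the only measured step bearing on this is a step that the two limits leave unreadable from compound 1 to compound 2, and it has no readable size. No shift beyond the scatter, in either direction, is therefore expected in this assay, and the expected step is a step that the limit leaves unreadable from compound 2 to compound 3. Compound 3 is estimated at 80 ug/mL, with an expected range of 40 ug/mL to 128 ug/mL.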

Compound 3, half-maximal inhibitory concentration: 48.5 ug/mL
The estimate for compound 3 lay 1.6-fold (0.22 log units) above the measured number; the range from low to high includes it.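

In this assay, within the data shown here, compound 3 is the only one of the three compounds with a readable number, so this saturated ring carbon is a place where a change can bring the value within the range of the assay. The record now holds an at least 1.3-fold lower number from compound 2 to compound 3 (0.12 log units; that floor lies within the scatter), and an at least 1.3-fold lower number from compound 1 to compound 3 (0.12 log units; that floor lies within the scatter). Both are floors, so their full size stays unknown, and the other two values remain limits: the limit of > 64 ug/mL in this assay, at which 2 of the 3 values shown sit.

The compounds shown leave open whether the nitrogen of methanesulfonamido is what matters here. They also leave open how an amine or a carboxylic acid on this ring carbon would read.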